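Ethoxy for methoxy on a chemokine receptor antagonist series

A few compounds are considered here, and "the series" means these few. Any claim that something is new, unique, unknown or untested is made for them only; others in the source may bear on it.

Measured compounds:
Compound 1, `C[C@@H]1CN(c2scnc2-c2nc3ccccc3[nH]2)CCN1C(=O)Cn1cnc2cccnc21`: 830 nM
Compound 2, `CC[C@@H]1CN(c2scnc2-c2nc3ccccc3[nH]2)CCN1C(=O)Cn1cnc2cccnc21`: 604 nM
Compound 3, `COc1ncc(-c2nc(C(F)(F)F)sc2N2CCN(C(=O)Cn3cnc4cccnc43)[C@H](C)C2)cn1`: 177 nM

All three were tested in a functional assay on U2OS cells for antagonist activity at C-X-C chemokine receptor type 3 (Homo sapiens), read by beta-arrestin recruitment; on this read-out lower numbers stand for stronger inhibition and higher numbers for weaker inhibition. Compound 1 and compound 2 share one core and differ in a single change, (methyl in place of hydrogen on a saturated chain carbon bound to a saturated ring carbon), which gave a 1.4-fold lower number from compound 1 to compound 2 (0.14 log units; within the scatter). Compound 3 has a different core; the difference between the two cores is not broken down here. What the values show is that compound 3 gives a lower number than compound 2 and compound 1, and both gaps lie beyond the scatter.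

Compound 4, `CCOc1ncc(-c2nc(C(F)(F)F)sc2N2CCN(C(=O)Cn3cnc4cccnc43)[C@H](C)C2)cn1`, has not yet been measured in this assay. It differs from compound 3 by methyl in place of hydrogen on a saturated chain carbon bound to an oxygen on an aromatic ring. Within the data shown here, this is the same kind of change as the one from compound 1 to compound 2, but not the same: there the new methyl sat on a saturated chain carbon bound to a saturated ring carbon, here it sits on a saturated chain carbon bound to an oxygen on an aromatic ring. Among the measured compounds shown here, with only one measured example of this kind of change, which stayed within the scatter, a small step is expected here too, a 1.2-fold lower number from compound 3 to compound 4 (0.07 log units; within the scatter), resting on the step from compound 1 to compound 2 and on compound 3 at 177 nM. For compound 4 the estimate in this assay is 150 nM, with a likely range from 60 nM to 400 nM.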

Compound 4, half-maximal inhibitory concentration: 20 nM
Estimate against measurement, compound 4: 7.5-fold (0.88 log units) above; measured number below the stated range.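

In this assay, replacing methoxy with ethoxy on the pyrimidine gave an 8.9-fold lower number from compound 3 to compound 4 (0.95 log units; beyond the scatter), a large step for the addition of a single methyl. Set beside the earlier step, this shows that a methyl added to a saturated chain carbon does not have one fixed size of effect in this series: the same change on two cores in this assay, a 1.4-fold lower number (0.14 log units; within the scatter) from compound 1 to compound 2 and an 8.9-fold lower number (0.95 log units; beyond the scatter) from compound 3 to compound 4, 6.4-fold (0.81 log units) apart, beyond the scatter of two such steps What this does not show is why the steps differ, since the two pairs differ in both the core and the place of the new methyl, on a saturated chain carbon bound to a saturated ring carbon in one pair and on a saturated chain carbon bound to an oxygen on an aromatic ring in the other, and two pairs cannot separate those influences or support a general rule.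

The compounds shown leave open whether a longer chain such as propoxy, or a branched one such as isopropoxy, would lower the number further on the core of compound 4. They also leave open whether methoxy to ethoxy would give a step of similar size if the trifluoromethyl group of compound 3 and compound 4 were replaced by a nitrile.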